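Swapping a small group for a much larger one

The source may hold more compounds than are shown below. What is called first, only, known or untested is meant among the compounds shown, and "the series" means these compounds.

In an ADME assay on L6 cells (Rattus norvegicus) for inhibition, read by resazurin assay, with a stated time of 72 h (on this read-out higher numbers stand for weaker inhibition and lower numbers for stronger inhibition), compound 2 `CC(=O)O[C@@H]1[C@H](OC(C)=O)[C@@H](C[S+](C)[O-])O[C@H]1n1cnc2c(N)nc(Cl)nc21` gives 168000 nM, level with compound 3 `CS(=O)(=O)C[C@H]1O[C@@H](n2cnc3c(N)nc(Cl)nc32)[C@H](O)[C@@H]1O` at 156000 nM. Compound 1 `CSC[C@H]1O[C@@H](n2cnc3c(N)nc(F)nc32)[C@H](OC(C)=O)[C@@H]1OC(C)=O` gives a clearly lower number, 15000 nM. Compound 4 `CC(=O)O[C@@H]1[C@H](OC(C)=O)[C@@H](CN2C(=O)c3ccccc3C2=O)O[C@H]1n1cnc2c(N)nc(Cl)nc21` changes compound 2 on a saturated chain carbon bound to a saturated ring carbon: a group of 11 heavy atoms (8 carbon, 1 nitrogen, 2 oxygen; one five-membered non-aromatic ring with 1 hetero atom, one six-membered aromatic ring of carbon only) in place of a group of 3 heavy atoms (1 carbon, 1 oxygen, 1 sulfur; no ring), on a saturated chain carbon bound to a saturated ring carbon. Among the compounds with values here, no measured pair differs in one place only, so the guidance is thin. Within the data shown here, compound 1 at 15000 nM shows only that numbers well under those of compound 2 occur in this set. A moderate move toward stronger inhibition, beyond the scatter, is expected, an estimated step of a 2.8-fold lower number from compound 2 to compound 4 (0.45 log units; beyond the scatter). The estimate for compound 4 is 60000 nM, with an expected range of 15000 nM to 200000 nM.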

Compound 4, half-maximal inhibitory concentration: 144000 nM
Estimate against measurement, compound 4: 2.4-fold (0.38 log units) below, and the stated range covers the measured number.
By their numbers in this assay, from the lowest: compound 1; then compounds 4, 3 and 2 (each within the scatter of the next).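

In this assay the swap gives a 1.2-fold lower number from compound 2 to compound 4 (0.07 log units; within the scatter) and so shows that, on a saturated chain carbon bound to a saturated ring carbon, a group of 11 heavy atoms with two rings reads level with a ringless group of 3 heavy atoms. Size at this place, across this one pair, therefore leaves the read-out within the scatter. Nothing measured here offers a cause for this. On these data alone, whether an amine or a longer chain on this carbon would also read level with compound 2 stays open. The lower number of compound 1 also remains unassigned, as that compound differs from the others in more than one place.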